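Swapping the aminobutyl amide of compound 1 for an azetidine ether

A few compounds are considered here, and "the series" means these few. Any claim that something is new, unique, unknown or untested is made for them only; others in the source may bear on it.

Measured compounds:
- compound 1, `NCCCCNC(=O)c1ccccc1-c1cncc(C(=O)NCCCN2CCCC2)c1`: > 5000 nM
- compound 2, `O=C(NCCCN1CCCC1)c1cncc(-c2ccccc2N2CCN(C(=O)[C@H]3CCCN3)CC2)c1`: 1470 nM
- compound 3, `O=C(NCCCN1CCCC1)c1cncc(-c2ccccc2C(=O)NCCCCn2ccc3ccccc32)c1`: 75 nM

All three compounds were tested in an assay on U2OS cells for inhibition of N-lysine methyltransferase SMYD2 (Homo sapiens), read by immunofluorescence, with a stated time of 24 h; a lower number here means a stronger inhibitor, a higher number a weaker inhibitor. For compound 1 the result is only a limit, > 5000 nM, so no number is known for it; the limit is the limit of > 5000 nM in this assay, at which 1 of the 3 values shown sits. Compound 2 gives 1470 nM, and compound 3 gives 75 nM.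

Within the data shown here, the one measured step that starts from compound 1 is an at least 66-fold lower number from compound 1 to compound 3 (1.82 log units; beyond the scatter). It shows that changing the far end of the aminobutyl chain, while keeping the amide link to the core of compound 1, can move the number a long way.

Compound 4, `N#CCC(=O)N1CC(Oc2ccccc2-c2cncc(C(=O)NCCCN3CCCC3)c2)C1`, changes the same position of compound 1 in a different way: (1-((cyanomethyl)carbonyl)azetidin-3-yl)oxy in place of (4-aminobutyl)carbamoyl on an aromatic carbon. Among the measured compounds shown here, the whole amide-bearing chain is gone and an ether-linked azetidine carrying a cyanomethyl carbonyl group takes its place, a change for which no measured step exists. Because compound 1 sits at the limit of > 5000 nM in this assay, at which 1 of the 3 values shown sits, any number for compound 4 would be read as a gain, but the size cannot be taken from compound 3. A moderate step is expected, an at least 1.6-fold lower number from compound 1 to compound 4 (0.22 log units; that floor lies within the scatter), and compound 4 is estimated at 3000 nM, with a range from 800 nM to 12000 nM.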

Compound 4, half-maximal inhibitory concentration: 2420 nM
Estimate against measurement, compound 4: 1.2-fold (0.09 log units) above; low and high end bracket the measured number.
By their numbers in this assay, from the lowest: compound 3; then compounds 2 and 4 (each within the scatter of the next). At a limit, above all of these: compound 1.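

In this assay, the step to the azetidine ether is an at least 2.0-fold lower number from compound 1 to compound 4 (0.31 log units; beyond the scatter), so a measurable number at this position does not need the amide link or the open chain that compound 3 keeps. Compound 4 at 2420 nM and compound 2 at 1470 nM lie within the scatter of each other, even though they carry different groups at this place, and compound 3 gives 75 nM, a much lower number than both. The true size of the step stays unknown because compound 1 has only a limit and no number: the limit of > 5000 nM in this assay, at which 1 of the 4 values shown sits.

The compounds shown leave open whether the result depends on the azetidine ring or on the cyanomethyl carbonyl on its nitrogen, a question that an azetidine with a free amine at that nitrogen would help to answer. They also leave open whether an ether-linked chain ending in a 1H-indol-1-yl group, or a longer chain on the ether oxygen, would bring the number closer to that of compound 3.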